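Aroylhydrazone versus guanylhydrazone on a bromochalcone core

The compounds below may be only part of what the source reports. "The series", "measured", "known", "first", "only" and "open" are said of these compounds alone.

Measured so far in a functional assay on the whole organism (Ear) for inhibition, with Mus musculus as the target, with a stated time of 30 min, at a dose of 100 mg/kg by the intraperitoneal route; a lower number here means less inhibition, a higher number more inhibition at the dose given (going by the name of the read-out):
compound 1 `O=C(/C=C/c1ccc(/C=N/NC(=O)c2ccncc2)cc1)c1ccc(Br)cc1` gives 55.7%
compound 2 `N=C(N)N/N=C/c1ccc(/C=C/C(=O)c2ccc(Br)cc2)cc1` gives 68.9%
compound 3 `N=C(N)N/N=C/c1ccc(/C=C/C(=O)c2ccccc2Br)cc1` gives 78.3%

The cores of compound 2 and compound 3 differ as 2-bromophenyl in place of 4-bromophenyl on a carbonyl carbon; the step in this assay was a number 9.4 percentage points higher from compound 2 to compound 3 (within the scatter). From compound 2 to compound 1 the change is a group of 8 heavy atoms (6 carbon, 1 nitrogen, 1 oxygen; one six-membered aromatic ring with 1 hetero atom) in place of a group of 3 heavy atoms (1 carbon, 2 nitrogen; no ring), on an amine nitrogen, and it gave a number 13.2 percentage points lower from compound 2 to compound 1 (beyond the scatter). Compound 4 `O=C(N/N=C/c1ccc(/C=C/C(=O)c2ccccc2Br)cc1)c1ccncc1` is not yet measured. Going by the values given here, it differs from compound 3 by a group of 8 heavy atoms (6 carbon, 1 nitrogen, 1 oxygen; one six-membered aromatic ring with 1 hetero atom) in place of a group of 3 heavy atoms (1 carbon, 2 nitrogen; no ring), on an amine nitrogen, the same change as from compound 2 to compound 1, at a place described in the same words, so the one measured precedent is carried over to the core of compound 3. In this assay compound 4 is therefore expected to give about 65%, likely between 50% and 78%. Among the compounds with values here, for compound 4 that means an estimated step of a number 13.3 percentage points lower from compound 3 to compound 4 (beyond the scatter), chosen because a number 13.2 percentage points lower from compound 2 to compound 1 (beyond the scatter) is the only guide, and a single pair leaves the range wide.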

Compound 4, a percentage reported as inhibition, in the whole organism at one dose (the size of the read-out at that dose, not a potency): 48.7%
For compound 4 the middle estimate is 16.3 percentage points above the measured one; measured number outside the range, below it.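

In this assay, (pyridin-4-yl)carbonyl on the amine nitrogen gives a lower number on both cores, now with a number 29.6 percentage points lower from compound 3 to compound 4 (beyond the scatter), but the size of the step does not carry over from one core to the other: the same change on two cores in this assay, a number 13.2 percentage points lower (beyond the scatter) from compound 2 to compound 1 and a number 29.6 percentage points lower (beyond the scatter) from compound 3 to compound 4, 16.4 percentage points apart, beyond the scatter of two such steps. The change from 4-bromophenyl to 2-bromophenyl on a carbonyl carbon, now seen as a number 7 percentage points lower from compound 1 to compound 4 (within the scatter), likewise gives a different result with each group on the amine nitrogen: the same change on two cores in this assay, a number 9.4 percentage points higher (within the scatter) from compound 2 to compound 3 and a number 7 percentage points lower (within the scatter) from compound 1 to compound 4, 16.4 percentage points apart, beyond the scatter of two such steps. These four compounds therefore support carrying over the direction of the first change but not its size, and they do not show why the steps differ or whether this holds for other cores.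

As far as these compounds go, it remains open whether the difference between cores needs bromine at all, as a plain phenyl or a chlorophenyl on the carbonyl carbon could show. From the compounds shown here alone, how an acetyl or benzoyl group on the amine nitrogen behaves on these cores also remains open.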